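Series notes: amide nitrogen substituent, propyl to tert-butyl

The source may report more compounds than this note shows. Statements on the series, on what has been measured and on what is new or still open speak of the compounds shown alone.

Measured compounds:
compound 1 `C=CC1=C(C(=O)NCCC)C(c2ccc(F)cc2)OC1`, > 100000 nM
compound 2 `C=CC1=C(C(=O)NC2CCCCC2)C(c2ccc(OC)c(OC)c2)OC1`, 5540 nM

In a functional assay on HeLa cells (Homo sapiens) for cytotoxicity, read by MTT assay, with a stated time of 24 h (on this read-out lower numbers stand for stronger inhibition and higher numbers for weaker inhibition), compound 1 gives only a limit, > 100000 nM, so no number is available for it. Among the measured compounds shown here, in the limit of > 100000 nM in this assay, at which 1 of the 2 values shown sits, compound 1 is the one member sitting at that boundary. Compound 2 differs from compound 1 in several places. In this assay, for the measured compounds named here, compound 2 gives 5540 nM; with no single-point step between the two, only the two values themselves can be set side by side.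

Compound 3 `C=CC1=C(C(=O)NC(C)(C)C)C(c2ccc(F)cc2)OC1` is not yet measured. It differs from compound 1 in one place: tert-butyl in place of propyl on an amide-type nitrogen. Since compound 1 is a limit, the only anchor is that boundary. Going by the values given here, no measured step informs this change, and with the starting point off the scale no useful direction can be read; the expectation is that the step from compound 1 to compound 3 stays within the scatter, a step that the limit leaves unreadable from compound 1 to compound 3, with a fair chance that the assay again reports only a limit. Compound 3 is therefore estimated at 120000 nM in this assay, with a range from 30000 nM to 400000 nM.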

Compound 3, half-maximal inhibitory concentration: > 100000 nM
Compound 3 ended at the assay's limit; the forecaster's own chance of this, stated with the estimate: 70%; the middle value does not contradict the limit.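

Compound 1 and compound 3 both end as limits, so tert-butyl in place of propyl on the amide-type nitrogen gives no readable step: the limit of > 100000 nM in this assay, at which 2 of the 3 values shown sit.

Left open is whether this change shifts the read-out in any compound that gives a number rather than a limit.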